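The compounds below may be only part of what the source reports. "The series", "measured", "known", "first", "only" and "open" are said of these compounds alone.

Measured so far:
compound 1, `CCC(=O)Nc1ccc(S(=O)(=O)Oc2ccccc2I)cc1`: 7200 nM in a functional assay on HT-1080 cells (Homo sapiens) for antiproliferative activity, read by sulforhodamine B assay, with a stated time of 48 h; a higher number here means a weaker inhibitor, a lower number a stronger inhibitor
compound 2, `CC(C)c1ccccc1OS(=O)(=O)c1ccc(NC(=O)NCCCCl)cc1`: 2700 nM in this assay

Compound 2 gives the lower of the two numbers, and compound 1 sits at a higher number by a gap beyond the usual scatter. Compound 3, `O=C(NCCCCl)Nc1ccc(S(=O)(=O)Oc2ccccc2I)cc1`, keeps the core of compound 2 and changes one spot: iodo in place of isopropyl on an aromatic carbon. Within the data shown here, no pair of measured compounds shows this single change on its own, so the expectation rests on the two values above. A modest move toward a higher number is expected, near the edge of the scatter: the expected step is a 1.4-fold higher number from compound 2 to compound 3 (0.15 log units; within the scatter). Compound 3 is estimated at 3800 nM, with a likely range from 1300 nM to 11000 nM.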

Compound 3, half-maximal inhibitory concentration: 2800 nM
Compound 3: the middle estimate sits 1.4-fold (0.13 log units) above what was measured; the measured number falls inside the stated range.
By their numbers in this assay, from the lowest: compounds 2 and 3 (each within the scatter of the next); then compound 1.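

In this assay, iodo in place of isopropyl on an aromatic carbon gives a 1.0-fold higher number from compound 2 to compound 3 (0.02 log units; within the scatter), so these two groups cannot be told apart at this spot, ortho to a large group. With the iodo group common to both compounds, (3-chloropropyl)amino in place of ethyl on a carbonyl carbon gives a 2.6-fold lower number from compound 1 to compound 3 (0.41 log units; beyond the scatter), a modest change beyond the scatter. Nothing at hand explains either result. From the compounds shown here alone, whether a methyl group, a methoxy group or an amine at the iodo position would also leave the number unchanged remains open.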